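This account rests on a few compounds, and the source may have more. Where it says the series, first, only, none or still open, it means among the compounds named here.

Measured compounds:
- compound 1, `ClCc1cccc(Cn2cnc3nc(Cl)nc(Cl)c32)c1`: 4160 nM
- compound 2, `ClCc1ccccc1Cn1cnc2nc(Cl)nc(Cl)c21`: 630 nM

In a functional assay on RPMI-8226 cells (Homo sapiens) for cytotoxicity, read by sulforhodamine B assay, with a stated time of 48 h (a higher number here means a weaker inhibitor of growth, a lower number a stronger inhibitor of growth), compound 2 gives 630 nM, the lowest of the two numbers. Compound 1 gives 4160 nM in this assay, a higher number that lies beyond the usual scatter of this kind of measurement, so compound 2 is the stronger inhibitor of growth of the pair.

Compound 3, `ClCc1ccccc1Cn1cnc2ncnc(Cl)c21`, has not yet been measured in this assay. It differs from compound 2 in one place: hydrogen in place of chloro on an aromatic carbon. Within the data shown here, no measured pair shows this change, so there is no step from which its size can be read. The change removes a chloro group from the shared core of compound 2 and puts nothing in its place, and the expectation is a modest loss of potency, a step that may or may not clear the scatter. Compound 3 is therefore expected to give about 1500 nM in this assay, with a range from 500 nM to 5000 nM. The expected step is a 2.4-fold higher number from compound 2 to compound 3 (0.38 log units; beyond the scatter), a rise rather than a fall.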

Compound 3, concentration for total growth inhibition: 5490 nM
For compound 3 the middle estimate is 3.7-fold (0.56 log units) below the measured one; measured number above the stated range.
By their numbers in this assay, from the lowest: compound 2; then compounds 1 and 3 (each within the scatter of the next).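

In this assay, putting hydrogen in place of the chloro group on the aromatic carbon between two ring nitrogen atoms gives an 8.7-fold higher number from compound 2 to compound 3 (0.94 log units; beyond the scatter), so this chloro group counts for growth inhibition in the setting of compound 2. The earlier compounds shown here both carry this chloro group, so they could say nothing about this position. The other chloro group on that ring is present in both compound 2 and compound 3, which confines the step to this one position. No measurement at hand explains the step.

On these data alone, it remains open whether an amine or a methoxy group at this position would hold the number of compound 2 or lose as much as hydrogen does. As far as these compounds go, it is also open whether the same change would have a step of similar size in compound 1.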